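Swapping methyl for fluoro on the benzyl ring

This account rests on a few compounds, and the source may have more. Where it says the series, first, only, none or still open, it means among the compounds named here.

Measured in a functional assay on SK-OV-3 cells (Homo sapiens) for cytotoxicity, read by MTT assay, with a stated time of 2 days; on this read-out higher numbers stand for weaker inhibition and lower numbers for stronger inhibition:
Compound 1 `CC(=O)Nc1ccc2c(c1)/C(=N\O)C(c1c[nH]c3ccc(NC(C)=O)cc13)=N2` gives 21300 nM.
Compound 2 `c1ccc(CO/N=C2/C(c3c[nH]c4ccccc34)=Nc3ccccc32)cc1` gives 16900 nM.
Compound 3 `Cc1ccc(CO/N=C2/C(c3c[nH]c4ccccc34)=Nc3ccccc32)cc1` gives 32400 nM.

Compound 3 has the highest number of the three, but its gaps to compound 1 and to compound 2 both lie within the usual scatter, so no order among them can be read. Going by the values given here, the only step among the measured pairs that bears on the next change is the one on the same ring: a 1.9-fold higher number from compound 2 to compound 3 (0.28 log units; within the scatter). Compound 4 `Fc1ccc(CO/N=C2/C(c3c[nH]c4ccccc34)=Nc3ccccc32)cc1` differs from compound 3 by fluoro in place of methyl on an aromatic carbon. Since the earlier change at this spot, from hydrogen to methyl, moved the number by less than the scatter, a further swap at the same spot is expected to do likewise. Compound 4 is therefore expected to give 25000 nM, with a range from 10000 nM to 60000 nM. The step expected from compound 3 to compound 4 is a 1.3-fold lower number from compound 3 to compound 4 (0.11 log units; within the scatter), which means no change beyond the scatter.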

Compound 4, half-maximal inhibitory concentration: 29000 nM
Compound 4: middle estimate off by 1.2-fold (0.06 log units), on the low side; the range from low to high includes it.
By their numbers in this assay, from the lowest: compounds 2, 1, 4 and 3 (each within the scatter of the next).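

In this assay this spot on the benzyl ring now carries hydrogen, methyl or fluoro, so the reading no longer rests on a single swap. Fluoro in place of methyl gives a 1.1-fold lower number from compound 3 to compound 4 (0.05 log units; within the scatter) and fluoro in place of hydrogen gives a 1.7-fold higher number from compound 2 to compound 4 (0.23 log units; within the scatter) so neither step to the new compound exceeds the scatter. Among these three groups, then, the read-out does not separate one from another at this position, and nothing at hand offers an explanation for that.

Going by these compounds, what stays open is whether any group at this spot can shift the number beyond the scatter, for example an amine, a carboxylic acid or a longer chain such as butyl. Equally open, on these data alone, is whether fluoro or methyl would behave the same way elsewhere on this ring.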